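Ester Variation and Tolerated Concentration in Liver Cells

The compounds below may be only part of what the source reports. "The series", "measured", "known", "first", "only" and "open" are said of these compounds alone.

Compounds measured so far:
compound 1, `CC(C)C(=O)OCCc1c(-c2ccccc2Cl)c2cc(Cl)ccc2[nH]c1=O`, 62000 nM
compound 2, `COCC(=O)OCCc1c(-c2ccccc2Cl)c2cc(Cl)ccc2[nH]c1=O`, 74000 nM

In an ADME assay on HepG2 2.2.15 cells (Homo sapiens) for cytotoxicity (a higher number here means that more compound is tolerated, a lower number that less compound is tolerated), compound 1 gives 62000 nM, and compound 2 gives 74000 nM. For the measured compounds named here, compound 2 stands against only one other compound, compound 1, and the step of a 1.2-fold higher number from compound 1 to compound 2 (0.08 log units; within the scatter) is within the scatter, so the two numbers cannot be told apart.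

Compound 3 is `O=C(OCCc1c(-c2ccccc2Cl)c2cc(Cl)ccc2[nH]c1=O)c1ccccc1`. It differs from compound 2 in one place: phenyl in place of methoxymethyl on a carbonyl carbon. The same carbonyl carbon is the spot that changed from compound 1 to compound 2, where a 1.2-fold higher number from compound 1 to compound 2 (0.08 log units; within the scatter) was the outcome. That single step is the only one that bears on the new change, and it was small; yet the entering phenyl is a ring, unlike either of the two earlier groups, so the earlier step is only a loose guide.

The estimate for compound 3 in this assay is therefore 55000 nM, with a likely range from 25000 nM to 120000 nM, meaning an expected step of a 1.3-fold lower number from compound 2 to compound 3 (0.13 log units; within the scatter) that may well stay within the scatter.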

Compound 3, half-maximal cytotoxic concentration: 43000 nM
Compound 3: the middle estimate sits 1.3-fold (0.11 log units) above what was measured; measured number inside the range.
By their numbers in this assay, from the lowest: compounds 3, 1 and 2 (each within the scatter of the next).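

For the compounds shown here, compound 3 is the first in this set with a ring on the carbonyl carbon, and it gives the first test of a ring at this position. In this assay, replacing methoxymethyl with phenyl gives a 1.7-fold lower number from compound 2 to compound 3 (0.24 log units; within the scatter), while replacing isopropyl with phenyl gives a 1.4-fold lower number from compound 1 to compound 3 (0.16 log units; within the scatter), so neither step can be separated from ordinary repeat-to-repeat variation. The position has now held two open-chain groups and a six-membered aromatic ring of carbon only, without any step in this set rising above that variation, although nothing available explains these results.

Going by these compounds alone, these three compounds show only that these particular groups cannot be told apart in this measure of tolerated concentration, so they do not establish that every group at this position would behave the same way. Going by these compounds, whether an amine, a carboxylic acid or a longer chain on the same carbonyl carbon would produce a clear step remains open, as does whether a ring bearing substituents would match the plain phenyl.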